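The source may hold more compounds than are shown below. What is called first, only, known or untested is meant among the compounds shown, and "the series" means these compounds.

In a functional assay on HepG2 cells (Homo sapiens) for antiproliferative activity, read by CCK-8 assay, with a stated time of 72 h (on this read-out higher numbers stand for weaker inhibition and lower numbers for stronger inhibition), compound 2 `CCc1ccc(C(=O)Nc2cccc(-c3oc4cc(-c5ccc(F)cc5)ccc4c(=O)c3O)c2)cc1` gives 20600 nM; the only other number shown belongs to compound 1 `O=C(Nc1cccc(-c2oc3cc(-c4ccc(F)cc4)ccc3c(=O)c2O)c1)c1ccc(F)cc1F`, which in this assay gives 26400 nM, so the two compounds stand level within the scatter. For the measured compounds named here, the single step between them, a 1.3-fold lower number from compound 1 to compound 2 (0.11 log units; within the scatter), bears directly on the question, since it too exchanges the aryl group on the carbonyl carbon of the amide. Compound 3 `COc1ccc(C(=O)Nc2cccc(-c3oc4cc(-c5ccc(F)cc5)ccc4c(=O)c3O)c2)c(F)c1` differs from compound 2 by 2-fluoro-4-methoxyphenyl in place of 4-ethylphenyl on a carbonyl carbon. Because a 1.3-fold lower number from compound 1 to compound 2 (0.11 log units; within the scatter) stayed within the scatter, the step in this assay from compound 2 to compound 3 is expected to stay within the scatter as well, with no direction to be read from the two numbers, and it is estimated as a 1.0-fold lower number from compound 2 to compound 3 (0.01 log units; within the scatter). Compound 3 is therefore expected to give about 20000 nM in this assay, with a range from 8000 nM to 50000 nM.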

Compound 3, half-maximal inhibitory concentration: 45300 nM
Beside the measured number, compound 3's estimate is 2.3-fold (0.36 log units) below it; the range from low to high includes it.
By their numbers in this assay, from the lowest: compounds 2, 1 and 3 (each within the scatter of the next, the first and the last beyond it).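

In this assay, the aryl group on the carbonyl carbon of the amide now makes a readable difference: 2-fluoro-4-methoxyphenyl in place of 4-ethylphenyl gives a 2.2-fold higher number from compound 2 to compound 3 (0.34 log units; beyond the scatter), a modest step, whereas the earlier exchange at this place stayed within the scatter. Methoxy in place of fluoro on an aromatic carbon gives a 1.7-fold higher number from compound 1 to compound 3 (0.23 log units; within the scatter), so that change alone cannot be told from the scatter, and only compound 2 and compound 3 stand apart. Nothing measured here accounts for this difference.

The compounds shown leave open whether an amine or a carboxylic acid on this aryl ring, or a longer alkyl chain in place of the ethyl, would shift the number in either direction. They also leave open how a saturated ring such as cyclohexyl would fare at this place.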